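Removing the Benzyl Ether from Compound 3

The compounds below may be only part of what the source reports. "The series", "measured", "known", "first", "only" and "open" are said of these compounds alone.

Compound 3 `CCCCCCCCCCCCCCC(COCc1ccccc1)N(CC)CC` has been measured in an ADME assay on cells (Splenocyte, Mus musculus, strain BALB/c) for cytotoxicity, read by MTT assay, tested at 1 ug/mL (on this read-out lower numbers stand for a weaker effect and higher numbers for a stronger effect at the one concentration tested), where compound 3 gives 14.1%. Among the three numbers measured so far this is the second highest: compound 1 `CCCCCCCCCCCCCCC(N)CO` gives 15.1%, which lies within the scatter of compound 3, while compound 2 `CCCCCCCCCCCCCCC(N)COCc1ccccc1` gives 0%, a gap that is beyond the scatter. Compound 4 `CCCCCCCCCCCCCCC(CO)N(CC)CC` has not yet been measured. It differs from compound 3 in one place: hydrogen in place of benzyl on an oxygen on a saturated carbon. Going by the values given here, one measured step bears directly on this change, read in the opposite direction: a number 15.1 percentage points lower from compound 1 to compound 2 (beyond the scatter). The other step, a number 14.1 percentage points higher from compound 2 to compound 3 (beyond the scatter), concerns the amine rather than the ether, though it shows that compound 3 returns close to the number of compound 1. If the step tied to the benzyl carries over to the diethylamino pair, replacing the benzyl by hydrogen on compound 3 should raise the number by a modest amount, beyond the scatter. Among the compounds with values here, with only one such step to rest on, the expectation is uncertain. Compound 4 is therefore expected to give 25%, within a range of 8% to 42%. The expected step is a number 10.9 percentage points higher from compound 3 to compound 4 (beyond the scatter).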

Compound 4, a percentage reported as activity, at one concentration (the size of the read-out at that concentration, not a potency): 7.5%
Compound 4: the middle estimate sits 17.5 percentage points above what was measured, outside the stated range (below it).
By their numbers in this assay, from the lowest: compounds 2, 4, 3 and 1 (each within the scatter of the next, the first and the last beyond it).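

In this assay, hydrogen in place of benzyl on an oxygen on a saturated carbon gives a number 6.6 percentage points lower from compound 3 to compound 4 (within the scatter), so the change that mattered on the amino core does not show up beyond the scatter on the diethylamino core, and the two cores disagree: the same change on two cores in this assay, a number 15.1 percentage points lower (beyond the scatter) from compound 1 to compound 2 and a number 6.6 percentage points higher (within the scatter) from compound 4 to compound 3, 21.7 percentage points apart, beyond the scatter of two such steps. Diethylamino in place of amino behaves the same way, giving a number 7.6 percentage points lower from compound 1 to compound 4 (within the scatter) with the free hydroxy group present, while it gave a step beyond the scatter with the benzyl ether present: the same change on two cores in this assay, a number 14.1 percentage points higher (beyond the scatter) from compound 2 to compound 3 and a number 7.6 percentage points lower (within the scatter) from compound 1 to compound 4, 21.7 percentage points apart, beyond the scatter of two such steps. Going by these compounds alone, the two changes therefore do not act independently in these four compounds, and the only steps beyond the scatter are those that lead to or from compound 2, which combines the benzyl ether with the amino group.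

The compounds shown leave open whether this dependence extends to other groups on the oxygen, such as methyl or acetyl, to other amines, such as dimethylamino or a piperidine, or to a shorter chain. All of these numbers also come from a single concentration, so they say nothing about potency across a range of concentrations.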